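Nucleoside analogues: moving a furan ring on the shared core

The source may hold more compounds than are shown below. What is called first, only, known or untested is meant among the compounds shown, and "the series" means these compounds.

Measured compounds:
compound 1, `Nc1nc(N)c2c(-c3ccsc3)cn([C@@H]3O[C@H](CO)[C@@H](O)[C@H]3O)c2n1`; in an ADME assay on MRC5 cells (Homo sapiens), read by MTT assay, with a stated time of 72 h (a higher number here means a weaker inhibitor, a lower number a stronger inhibitor), compound 1 gives > 100000 nM, which is a limit of the assay and not a number.
compound 2, `Nc1nc(N)c2c(-c3ccoc3)cn([C@@H]3O[C@H](CO)[C@@H](O)[C@H]3O)c2n1`; in this assay compound 2 gives > 100000 nM, again a limit of the assay.
compound 3, `C#Cc1cn([C@@H]2O[C@H](CO)[C@@H](O)[C@H]2O)c2ncnc(C)c12`; in this assay compound 3 gives 1440 nM.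

Compound 2 stands at a limit in this assay, so its true value is not known as a number, and among the three values shown it shares that position with one other: the limit of > 100000 nM in this assay, at which 2 of the 3 values shown sit. Among the measured compounds shown here, the one step measured between neighbours, a step that the two limits leave unreadable from compound 1 to compound 2, is one that the two limits leave unreadable, so its size tells nothing about how the furan-3-yl group behaves. For the measured compounds named here, compound 3 differs from compound 2 in more than one place, so its value alone gives no step to read from.

The unmeasured compound 4, `Nc1nc(N)c2c(-c3ccco3)cn([C@@H]3O[C@H](CO)[C@@H](O)[C@H]3O)c2n1`, differs from compound 2 in one place: furan-2-yl in place of furan-3-yl on an aromatic carbon. Going by the values given here, no measured step bears on this change, because a step that the two limits leave unreadable from compound 1 to compound 2 is unreadable and no other pair is comparable. The expectation therefore rests only on where compound 2 stands, and no step beyond the scatter is expected for a number no higher from compound 2 to compound 4 (the limit leaves the size open). Compound 4 is thus estimated to remain near the limit in this assay, at 100000 nM, with a range from 30000 nM to 300000 nM.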

Compound 4, half-maximal inhibitory concentration: > 100000 nM
Compound 4 gave a limit, no number (the forecaster's own chance of this, stated with the estimate: 85%); the middle value lies on the limit itself.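

Compound 4 ends at a limit of the assay, as compound 1 and compound 2 do, so no step among these three compounds can be read, and their furan-2-yl, furan-3-yl and thiophen-3-yl groups cannot be ranked: the limit of > 100000 nM in this assay, at which 3 of the 4 values shown sit. As far as these compounds go, what stays open is the true value of each of the three in this assay and whether moving the furan ring changes it at all.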